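The source may report more compounds than this note shows. Statements on the series, on what has been measured and on what is new or still open speak of the compounds shown alone.

Measured so far: compound 2 `CSc1ccc(CNc2nc(SC)nc3ccccc23)cc1` and compound 1 `COc1ccc(CNc2nc([Se]C)nc3ccccc23)cc1`. In a functional assay on HTB-54 cells (Homo sapiens) for cytotoxicity, read by MTT assay, with a stated time of 72 h (a higher number here means a weaker inhibitor of growth, a lower number a stronger inhibitor of growth), compound 2 gives 44500 nM. For compound 1 this assay reports only a limit, > 100000 nM.

Compound 2 therefore holds the only number shown in this assay; the other value sits at the limit of > 100000 nM in this assay, at which 1 of the 2 values shown sits. Compound 3 `CSc1ccc(CNc2nc([Se]C)nc3ccccc23)cc1` is the next member to be measured. It differs from compound 2 by a group of 2 heavy atoms (1 carbon, 1 selenium; no ring) in place of a group of 2 heavy atoms (1 carbon, 1 sulfur; no ring), on an aromatic carbon. For the measured compounds named here, no measured pair covers this exchange on its own, since compound 1 and compound 2 differ in two places at once, and compound 1 shows only a limit. The size of the step in this assay is thus open; a change of no more than the usual scatter is expected, with some chance that compound 3 also ends at the limit. The estimated step from compound 2 to compound 3 is a 1.2-fold higher number from compound 2 to compound 3 (0.09 log units; within the scatter). For compound 3 the expected value is 55000 nM, within 15000 nM to 150000 nM.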

Compound 3, concentration for total growth inhibition: 72400 nM
For compound 3 the middle estimate is 1.3-fold (0.12 log units) below the measured one, and the stated range covers the measured number.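

In this assay, the group of carbon and selenium in place of methylsulfanyl, on the aromatic carbon between two ring nitrogen atoms, gives a 1.6-fold higher number from compound 2 to compound 3 (0.21 log units; within the scatter), so this position carries either group with no step beyond the scatter. With the selenium-bearing group held fixed, methylsulfanyl in place of methoxy on an aromatic carbon gives an at least 1.3-fold lower number from compound 1 to compound 3 (0.14 log units; that floor lies within the scatter), and that figure is only a floor. Compound 1 gives a limit of the assay and not a number: the limit of > 100000 nM in this assay, at which 1 of the 3 values shown sits.

As far as these compounds go, whether a different group at the position between the two ring nitrogen atoms, such as an amine or a longer chain, would give a step beyond the scatter stays open. From the compounds shown here alone, the true size of the methoxy to methylsulfanyl step also stays open, as does the reading of either exchange on any other cell line.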